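The compounds below may be only part of what the source reports. "The series", "measured", "known", "first", "only" and "open" are said of these compounds alone.

Measured compounds in an assay on cells for agonist activity at vitamin D3 receptor (Homo sapiens), with a stated time of 96 h; on this read-out higher numbers stand for an effect only at larger amounts of compound and lower numbers for an effect already at smaller amounts:
- compound 1 `CCn1c(C(=O)NCCCN(C)C)ccc1C(CC)(CC)c1ccc(OCCC(O)(CC)CC)c(C)c1`: 5 nM
- compound 2 `C#CC(C)OC(=O)c1ccc(C(CC)(CC)c2ccc(OCCC(O)(CC)CC)c(C)c2)n1CC`: 2650 nM
- compound 3 `CCOC(=O)CN(C)C(=O)c1ccc(C(CC)(CC)c2ccc(OCCC(O)(CC)CC)c(C)c2)n1CC`: 520 nM

On these three numbers compound 3 sits in the middle: it is a step of a 5.1-fold lower number from compound 2 to compound 3 (0.71 log units; beyond the scatter) away from compound 2 and a step of a 100-fold higher number from compound 1 to compound 3 (2.02 log units; beyond the scatter) away from compound 1, so the shared core with a carbonyl on the ring tolerates wide variation at this one position.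

Compound 4 `CCC(C)C(CO)NC(=O)c1ccc(C(CC)(CC)c2ccc(OCCC(O)(CC)CC)c(C)c2)n1CC` is not yet measured. It differs from compound 3 by (1-(hydroxymethyl)-2-methylbutyl)amino in place of ((ethoxycarbonyl)methyl)(methyl)amino on a carbonyl carbon. Going by the values given here, two measured steps bear on the question. The step of a 5.1-fold lower number from compound 2 to compound 3 (0.71 log units; beyond the scatter) shows that exchanging an oxy substituent for an amino substituent on this carbonyl carbon lowers the number. The step of a 100-fold higher number from compound 1 to compound 3 (2.02 log units; beyond the scatter) shows that among the amino substituents the choice of chain matters a great deal, with compound 1, which like compound 4 carries an amino substituent bearing a hydrogen on its nitrogen, giving by far the lowest number. Compound 4 introduces hydrogen-bond donors that compound 3 lacks, and its nearest measured relative by carbonyl substituent type is compound 1 rather than compound 2.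

In this assay compound 4 is therefore expected to give a lower number than compound 3, a step of about a 6.5-fold lower number from compound 3 to compound 4 (0.81 log units; beyond the scatter), estimated at 80 nM with a plausible range from 15 nM to 400 nM.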

Compound 4, half-maximal effective concentration: 450 nM
Compound 4: middle estimate off by 5.6-fold (0.75 log units), on the low side, outside the stated range (above it).
By their numbers in this assay, from the lowest: compound 1; then compounds 4 and 3 (each within the scatter of the next); then compound 2.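

Notes on the substituent on the carbonyl carbon, read in this assay: replacing ((ethoxycarbonyl)methyl)(methyl)amino with (1-(hydroxymethyl)-2-methylbutyl)amino gives a 1.2-fold lower number from compound 3 to compound 4 (0.06 log units; within the scatter), so hydrogen-bond donors on this substituent do not by themselves separate these two amino substituents. With the amide hydrogen present in both compounds, the change of 3-(dimethylamino)propyl to 1-(hydroxymethyl)-2-methylbutyl gives a 90-fold higher number from compound 1 to compound 4 (1.95 log units; beyond the scatter), which ties the low number of compound 1 to its chain and not to the amide hydrogen alone. Modest in size is a 5.9-fold lower number from compound 2 to compound 4 (0.77 log units; beyond the scatter), and so is a 5.1-fold lower number from compound 2 to compound 3 (0.71 log units; beyond the scatter). No measurement available here accounts for any of these steps.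

As far as these compounds go, it remains open which part of the 3-(dimethylamino)propyl chain goes with the low number of compound 1, a question that a 3-hydroxypropyl chain, a plain butyl chain, or a dimethylamino group on a shorter or longer chain could address. Also open, from the compounds shown here alone, is how a carboxylic acid in place of the ethyl ester of compound 3 would read, and whether the hydroxymethyl group or the branched alkyl part of compound 4 has any separate effect on the number.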